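A few compounds are considered here, and "the series" means these few. Any claim that something is new, unique, unknown or untested is made for them only; others in the source may bear on it.

In a functional assay on Huh-7 cells (Homo sapiens) for cytotoxicity, read by MTT assay, with a stated time of 72 h (a higher number here means that more compound is tolerated, a lower number that less compound is tolerated), the three measured compounds give only limits:
compound 1 `CCS(=O)(=O)N1CCC2(CC1)OOC1(CCCCC1)OO2`: > 100 ug/mL, a limit of the assay.
compound 2 `CCCS(=O)(=O)N1CCC2(CC1)OOC1(CCCC1)OO2`: > 100 ug/mL, a limit of the assay.
compound 3 `CCCS(=O)(=O)N1CCC2(CC1)OOC1(CCCCC1)OO2`: > 100 ug/mL, a limit of the assay.

Compound 1 and compound 2 share the same atoms joined differently; the difference between the two cores is not broken down here. Compound 3 arises from compound 1 by methyl in place of hydrogen on a saturated chain carbon, two bonds along the chain from a sulfonyl sulfur, and the step that the two limits leave unreadable from compound 1 to compound 3 cannot be read because of the limit of > 100 ug/mL in this assay, at which 3 of the 3 values shown sit. Compound 4 `CCCCS(=O)(=O)N1CCC2(CC1)OOC1(CCCC1)OO2` arises from compound 2 by methyl in place of hydrogen on a saturated chain carbon, three bonds along the chain from a sulfonyl sulfur, the same kind of change, the place differing in that the carbon lies three bonds rather than two bonds along the chain from the sulfonyl sulfur. Resting on compound 2 at > 100 ug/mL and on the unreadable step from compound 1 to compound 3, the step from compound 2 to compound 4 is expected to be a step that the limit leaves unreadable from compound 2 to compound 4. Compound 4 is estimated at 150 ug/mL in this assay, between 70 ug/mL and 400 ug/mL.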

Compound 4, half-maximal cytotoxic concentration: > 100 ug/mL
Compound 4 ended at the assay's limit; the forecaster's own chance of this, stated with the estimate: 80%; the middle value lies beyond the limit too.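

No step can be read from compound 2 to compound 4 in this assay, since both values are limits: the limit of > 100 ug/mL in this assay, at which 4 of the 4 values shown sit.

The compounds shown leave open whether the sulfonyl chain or the core changes tolerance in this assay at all.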